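This account rests on a few compounds, and the source may have more. Where it says the series, first, only, none or still open, it means among the compounds named here.

Measured so far:
- compound 1 `C[C@H](CN1CCC(F)CC1)NC(=O)c1ccc(-c2noc(C(F)(F)F)n2)cc1` — 30 nM
- compound 2 `CC(C)(CN1CCCC1)NC(=O)c1ccc(-c2noc(C(F)(F)F)n2)cc1` — 280 nM
- compound 3 `CCCN(CCC)C[C@@H](C)NC(=O)c1ccc(-c2noc(C(F)F)n2)cc1` — 890 nM

All three were tested in an assay on isolated protein for inhibition of histone deacetylase 4 (Homo sapiens), read by fluorescence; a lower number here means a stronger inhibitor, a higher number a weaker inhibitor. Compound 1 gives the lowest number of the three; compound 2 and compound 3 both sit clearly higher, and both of those gaps lie beyond the usual scatter of this assay. Within the data shown here, the two weaker compounds differ from compound 1 in more than one place at once, so no single step between measured compounds can be read off.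

The next compound, compound 4 `C[C@H](CN1CCCC(C)(C)C1)NC(=O)c1ccc(-c2noc(C(F)(F)F)n2)cc1`, keeps the shared core of compound 1 and changes only the ring at the end of the chain: 3,3-dimethylpiperidin-1-yl in place of 4-fluoropiperidin-1-yl on a saturated chain carbon, two bonds along the chain from an amide-type nitrogen. A fluorine-bearing ring leaves and a ring carrying two methyl groups enters, at the same place on the chain. Among the measured compounds shown here, with no measured step to lean on, the expectation is a small to moderate loss, of a size that may or may not exceed the scatter, as the step of a 2.3-fold higher number from compound 1 to compound 4 (0.37 log units; beyond the scatter) expresses. Compound 4 is therefore estimated at 70 nM, with a plausible range from 20 nM to 300 nM.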

Compound 4, half-maximal inhibitory concentration: 2 nM
Compound 4: the middle estimate sits 35-fold (1.54 log units) above what was measured; measured number outside the range, below it.
By their numbers in this assay, from the lowest: compound 4; then compound 1; then compound 2; then compound 3.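

In this assay, the ring at the end of the chain proves to matter a great deal: 3,3-dimethylpiperidin-1-yl in place of 4-fluoropiperidin-1-yl brings a 15-fold lower number from compound 1 to compound 4 (1.18 log units; beyond the scatter). Among these compounds, the earlier compounds differed in more than one place at once, so this is the first change that can be read on its own, and it shows that this place on the chain can shift the number strongly while the rest of the molecule stays the same. Nothing available here explains why the step is so large.

Whether the two methyl groups, the loss of the fluorine or both account for the step stays open, and a plain piperidin-1-yl ring, carrying neither, would help separate them. Also open, on these data alone, is how a 3-methylpiperidin-1-yl ring or a morpholine ring would fare at this place.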